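The source may report more compounds than this note shows. Statements on the series, on what has been measured and on what is new or still open speak of the compounds shown alone.

Working notes on the amine variation of the shared core. Compound 1 `CCCCN(CC)Cc1c(C(F)(F)F)nc2n(-c3c(C)cc(C)cc3C)c(Cl)cn12` gives 78 nM in an assay on cells for displacement of a labelled ligand from corticotropin-releasing factor receptor 1 (Homo sapiens), with a stated time of 100 min; a lower number here means a stronger inhibitor, a higher number a weaker inhibitor. Among the compounds with values here, compound 2 `CCCN(Cc1ccccc1)Cc1c(C(F)(F)F)nc2n(-c3c(C)cc(C)cc3C)c(Cl)cn12` gives 170 nM in this assay and so carries the higher of the two numbers measured so far; the recorded step is a 2.2-fold higher number from compound 1 to compound 2 (0.34 log units; beyond the scatter), a modest move. Compound 3 `Cc1cc(C)c(-n2c(Cl)cn3c(CN4CCCCC4)c(C(F)(F)F)nc23)c(C)c1` has not been measured; it differs from compound 2 by piperidin-1-yl in place of benzyl(propyl)amino on a saturated chain carbon bound to an aromatic carbon. Within the data shown here, the only measured step at this place is the exchange of one open-chain amine for another, which moved the number only modestly, and no measured pair shows what replacing an open-chain amine by piperidin-1-yl does. The direction of the new step therefore cannot be read from the data, and a change of small size, if any beyond the scatter, is expected. On this basis the expected step is a 1.1-fold lower number from compound 2 to compound 3 (0.05 log units; within the scatter). Compound 3 is estimated at 150 nM, within a range from 50 nM to 450 nM.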

Compound 3, inhibition constant: 1200 nM
For compound 3 the middle estimate is 8.0-fold (0.90 log units) below the measured one, and the stated range ends below it.
By their numbers in this assay, from the lowest: compound 1; then compound 2; then compound 3.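

In this assay, the amine on the saturated chain carbon bound to an aromatic carbon proves more sensitive than the exchange of one open-chain amine for another had shown: piperidin-1-yl gives a 7.1-fold higher number from compound 2 to compound 3 (0.85 log units; beyond the scatter) and a 15-fold higher number from compound 1 to compound 3 (1.19 log units; beyond the scatter) and leaves compound 3 the weakest inhibitor of the three. Loss of the six-membered aromatic ring alone does not account for this rise, as compound 1 also lacks that ring and carries the lowest number. No measurement on hand gives a reason for the rise.

From the compounds shown here alone, whether the rise belongs to piperidin-1-yl alone or extends to other cyclic amines, such as pyrrolidin-1-yl or morpholin-4-yl, remains open. Also open, going by these compounds, is how far longer open chains on the amine, such as dibutylamino, would move the number.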